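Para-substituent swap on the benzylamine arm: phenyl to pyridin-4-yl

This account rests on a few compounds, and the source may have more. Where it says the series, first, only, none or still open, it means among the compounds named here.

Compound 2 `FC(F)(F)c1ccccc1-c1nc(NCc2ccc(-c3ccccc3)cc2)c2ccccc2n1` gives 3700 nM in an assay on a protein complex for inhibition of ubiquitin carboxyl-terminal hydrolase 1/WD repeat-containing protein 48 (Homo sapiens), read by fluorescence; a lower number here means a stronger inhibitor, a higher number a weaker inhibitor; its nearest neighbour is compound 1 `FC(F)(F)c1ccccc1-c1nc(NCc2ccc(Cl)cc2)c2ccccc2n1` at 4800 nM, and the step of a 1.3-fold lower number from compound 1 to compound 2 (0.11 log units; within the scatter) is within the scatter, so compound 2 cannot be ranked against compound 1. Compound 3 `FC(F)(F)c1ccccc1-c1nc(NCc2ccc(-c3ccncc3)cc2)c2ccccc2n1` carries pyridin-4-yl in place of phenyl on an aromatic carbon. Going by the values given here, the only measured step, from compound 1 to compound 2, changes the same position and is within the scatter; no step touches a ring-nitrogen swap. Expect a 1.1-fold higher number from compound 2 to compound 3 (0.03 log units; within the scatter), no change beyond the scatter, in this assay. The estimate for compound 3 is 4000 nM, range 1500 nM to 10000 nM.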

Compound 3, half-maximal inhibitory concentration: 1900 nM
Beside the measured number, compound 3's estimate is 2.1-fold (0.32 log units) above it, within the range that was stated.
By their numbers in this assay, from the lowest: compounds 3, 2 and 1 (each within the scatter of the next, the first and the last beyond it).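

In this assay, putting the ring nitrogen of pyridin-4-yl in place of phenyl stays within the scatter (a 1.9-fold lower number from compound 2 to compound 3 (0.29 log units; within the scatter)), so this swap alone cannot be ranked. Against chloro, however, pyridin-4-yl gives the first step at this position to pass the scatter, though only modestly (a 2.5-fold lower number from compound 1 to compound 3 (0.40 log units; beyond the scatter)). Nothing available explains either step.

Still open, on these data alone, is whether the ring nitrogen matters at all here, as phenyl and pyridin-4-yl cannot be separated. Pyridin-3-yl or a morpholine on this aromatic carbon would test how far the trend extends.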